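Swapping Fluoro for Methoxy in Compound 2

This account rests on a few compounds, and the source may have more. Where it says the series, first, only, none or still open, it means among the compounds named here.

Compound 2 `Cc1ccc(C(=O)N2CCN(CC(=O)N3CCN(CCCc4c[nH]c5ccc(F)cc45)CC3)CC2)cc1` in an ADME assay on HEK293 cells (Homo sapiens) for cytotoxicity, read by MTT assay, with a stated time of 72 h (a higher number here means a weaker inhibitor, a lower number a stronger inhibitor), gives 141000 nM. It stands level with compound 1 `COc1ccc(C(=O)N2CCN(CC(=O)N3CCN(CCCc4c[nH]c5ccc(F)cc45)CC3)CC2)cc1`, which gives 141000 nM, the two together the highest of the three numbers; compound 3 `O=C(CN1CCN(C(=O)c2cccc(Br)c2)CC1)N1CCN(CCCc2c[nH]c3ccc(F)cc23)CC1` gives 40600 nM, and the step of a 3.5-fold lower number from compound 2 to compound 3 (0.54 log units; beyond the scatter) is modest. The move to compound 4 `COc1ccc2[nH]cc(CCCN3CCN(C(=O)CN4CCN(C(=O)c5ccc(C)cc5)CC4)CC3)c2c1` puts (methoxy in place of fluoro on an aromatic carbon). For the measured compounds named here, no measured step touches that ring: no change at the digits printed from compound 1 to compound 2 (within the scatter) and a 3.5-fold lower number from compound 1 to compound 3 (0.54 log units; beyond the scatter) both alter the group on the carbonyl carbon, so they bear only loosely on this change, and the nearest analogy, a small exchange on an aromatic carbon from compound 1 to compound 2, moved nothing. Compound 4 is therefore expected to give 141000 nM (range 60000 nM to 250000 nM), a step of no change at the digits printed from compound 2 to compound 4 (within the scatter) that is expected to stay within the scatter.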

Compound 4, half-maximal inhibitory concentration: 147000 nM
Estimate against measurement, compound 4: 1.0-fold (0.02 log units) below; measured number inside the range.
By their numbers in this assay, from the lowest: compound 3; then compounds 1, 2 and 4 (each within the scatter of the next).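

For the compounds shown here, the step of a 1.0-fold higher number from compound 2 to compound 4 (0.02 log units; within the scatter) in this assay gives the first reading at this position, since the earlier steps all altered the group on the carbonyl carbon. With 4-methylphenyl held on that carbonyl carbon, methoxy in place of fluoro on this aromatic carbon stays within the scatter. Nothing available explains this result.

As far as these compounds go, whether an amine or a hydroxyl group at this position would read the same remains open. So does whether methoxy here would behave alike with the 3-bromophenyl group of compound 3 on the carbonyl carbon.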